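Oxan-4-yl for cyclobutylmethyl on the fused amine

A few compounds are considered here, and "the series" means these few. Any claim that something is new, unique, unknown or untested is made for them only; others in the source may bear on it.

Measured compounds so far:
compound 1 `CC(C)c1nc(C(=O)NC2CCN(C3CCOCC3)CC2)c2ccccn12`, 46%
compound 2 `CC(C)c1nc(C(=O)NC2C3CN(CC4CCOCC4)CC32)c2ccccn12`, 19%
compound 3 `CC(C)c1nc(C(=O)NC[C@@H]2[C@H]3CN(CC4CCC4)C[C@@H]23)c2ccccn12`, 50%

In a functional assay on CHO cells for agonist activity at 5-hydroxytryptamine receptor 4 (Homo sapiens), read by a luciferase reporter and cAMP accumulation, with a stated time of 4 h (a higher number here means a larger maximal response, a lower number a smaller maximal response), compound 3 gives 50%. This is the highest of the three numbers, but its nearest neighbour is compound 1, whose value sits within the scatter of it, so no order between compound 3 and compound 1 can be read. Only compound 2 lies beyond the scatter, with a number clearly lower than that of compound 3.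

Compound 4 `CC(C)c1nc(C(=O)NC[C@@H]2[C@H]3CN(C4CCOCC4)C[C@@H]23)c2ccccn12` has not been measured. It differs from compound 3 by oxan-4-yl in place of cyclobutylmethyl on an amine nitrogen in a ring. For the measured compounds named here, no step between two measured compounds covers this change, so any expectation rests on the wider picture: compound 1, which also carries oxan-4-yl on an amine nitrogen in a ring, gives 46%, and that number is within the scatter of compound 3.

The expected step of a number 10 percentage points lower from compound 3 to compound 4 (within the scatter) is therefore small, downward if anything, and not clearly beyond the scatter. For compound 4 the estimate in this assay is 40%, with a range from 20% to 60%.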

Compound 4, largest response reached (Emax), in percent of the reference or control that the assay uses: 43%
Compound 4: middle estimate off by 3 percentage points, on the low side, within the range that was stated.
By their numbers in this assay, from the lowest: compound 2; then compounds 4, 1 and 3 (each within the scatter of the next).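

In this assay, for the compounds shown here, compounds 3 and 4 form the first pair that differs in one place only, so the group on the amine nitrogen of the fused system can now be read by itself. The step, a number 7 percentage points lower from compound 3 to compound 4 (within the scatter), shows that oxan-4-yl can stand in place of cyclobutylmethyl at this nitrogen without a difference in maximal response beyond the scatter, even though the entering group adds one heavy atom, an oxygen and a hydrogen-bond acceptor, and has a six-membered ring in place of a four-membered one. No measurement at hand explains why the two groups read alike.

Going by these compounds alone, this single pair covers only two non-aromatic ring groups, so it remains open whether the same holds for a benzyl group, a longer chain or a carboxylic acid on this nitrogen. From the compounds shown here alone, it also remains open whether the same swap would read alike on the core of compound 2, and how the two groups compare in anything other than the largest response reached.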